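Trimming the amide side chain: compound 3 to compound 4

The source may hold more compounds than are shown below. What is called first, only, known or untested is meant among the compounds shown, and "the series" means these compounds.

Measured compounds in an ADME assay on Vero cells (Chlorocebus sabaeus) for cytotoxicity; on this read-out higher numbers stand for lower toxicity in this test and lower numbers for higher toxicity in this test:
compound 1, `O=C(O)CCC(=O)Nc1ccc(-c2nc3cc(C(F)(F)F)ccc3[nH]2)cc1`, gives > 100000 nM, a limit of the assay
compound 2, `COc1ccc(-c2nc3cc(C(F)(F)F)ccc3[nH]2)cc1`, gives 15000 nM
compound 3, `O=C(CN1CCCC1)Nc1ccc(-c2nc3ccccc3[nH]2)cc1`, gives > 100000 nM, a limit of the assay

Compound 3 stands at the upper limit of this assay, so its value is not a number; it sits at the limit of > 100000 nM in this assay, at which 2 of the 3 values shown sit. Among the measured compounds shown here, compound 2 is the only compound of the three with a measured number. For the measured compounds named here, the one measured step, an at least 6.6-fold lower number from compound 1 to compound 2 (0.82 log units; beyond the scatter), methoxy in place of ((2-carboxyethyl)carbonyl)amino on an aromatic carbon, brought the number down from the limit into the measurable range.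

Compound 4, `CCC(=O)Nc1ccc(-c2nc3ccccc3[nH]2)cc1`, differs from compound 3 by methyl in place of pyrrolidin-1-yl on a saturated chain carbon bound to a carbonyl carbon. Going by the values given here, no measured step covers this change: the only step in hand removes the whole amide arm, whereas here the amide stays and only the pyrrolidin-1-yl gives way to methyl. The step in this assay from compound 3 to compound 4 is therefore expected to be none beyond the scatter, a number no higher from compound 3 to compound 4 (the limit leaves the size open). For compound 4 the estimate in this assay is 100000 nM, with a range from 30000 nM to 300000 nM, and a fair chance that the assay again reports only a limit.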

Compound 4, half-maximal cytotoxic concentration: > 100000 nM
Compound 4: no number, only a limit (the forecaster's own chance of this, stated with the estimate: 60%); the middle value lies on the limit itself.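

In this assay, compound 3 and compound 4 both stop at the assay limit, so no step between them can be read: the limit of > 100000 nM in this assay, at which 3 of the 4 values shown sit.

The compounds shown leave open whether methyl in place of pyrrolidin-1-yl on this saturated chain carbon shifts the read-out at all, and what actual number either compound would give.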